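Swapping a pyrrole for an imidazole on the propyl chain

The source may hold more compounds than are shown below. What is called first, only, known or untested is meant among the compounds shown, and "the series" means these compounds.

Measured compounds:
compound 1 `Cn1cc(C2=C(c3n[nH]c4ncccc34)C(=O)N(c3cccc4ccccc34)C2=O)c2ccccc21`, > 100000 nM
compound 2 `Cn1cc(C2=C(c3nn(CCCn4cccc4)c4ncccc34)C(=O)N(c3ccccc3)C2=O)c2ccccc21`, 36600 nM
compound 3 `Cn1cc(C2=C(c3nn(CCCN4CCCCC4)c4ncccc34)C(=O)N(c3ccc(Cl)cc3)C2=O)c2ccccc21`, 1800 nM
compound 4 `Cn1cc(C2=C(c3nn(CCCn4ccnc4)c4ncccc34)C(=O)N(c3ccccc3)C2=O)c2ccccc21`, not yet measured

All four compounds share the same core and differ in the group hanging from an aromatic nitrogen and in the aryl group on the imide nitrogen. In a functional assay on K562 cells (Homo sapiens) for antiproliferative activity, read by MTT assay, with a stated time of 48 h (a higher number here means a weaker inhibitor, a lower number a stronger inhibitor), compound 2 gives 36600 nM, the higher of the two numbers that were obtained. Compound 3 gives 1800 nM in this assay, a gap beyond the usual scatter, though compound 3 differs from compound 2 in two places at once, so that gap cannot be pinned to either change. Compound 1 reaches only the limit of this assay, > 100000 nM; this is the situation described by the limit of > 100000 nM in this assay, at which 1 of the 3 values shown sits.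

Compound 4 differs from compound 2 in one place: 1H-imidazol-1-yl in place of 1H-pyrrol-1-yl on a saturated chain carbon, three bonds along the chain from an aromatic nitrogen. Among the compounds with values here, no measured pair isolates this change. A modest step toward a lower number is expected, a 1.8-fold lower number from compound 2 to compound 4 (0.26 log units; within the scatter), staying within a few multiples of the value of compound 2. Compound 4 is therefore estimated at 20000 nM in this assay, with a likely range from 6000 nM to 60000 nM.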

Compound 4, half-maximal inhibitory concentration: 5510 nM
Compound 4: middle estimate off by 3.6-fold (0.56 log units), on the high side; the measured number lies below the stated range.
By their numbers in this assay, from the lowest: compound 3; then compound 4; then compound 2. At a limit, above all of these: compound 1.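

In this assay, within the data shown here, this pair gives the first reading of a single change, a 6.6-fold lower number from compound 2 to compound 4 (0.82 log units; beyond the scatter). The step shows that the ring at the end of the propyl chain matters: 1H-imidazol-1-yl in place of 1H-pyrrol-1-yl leaves the chain itself untouched, yet moves the number beyond the usual scatter. The earlier gap between compound 2 and compound 3 could not be pinned to either of its two changes, whereas this one belongs to the ring swap alone.

Nothing measured here gives a reason for the step. Also open, going by these compounds, is how a morpholine at the end of the chain or a longer chain would compare, and whether the same swap gives a similar step with a different aryl group on the imide nitrogen.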